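Adding a Second Methoxy Group to a Growth Inhibitor

This account rests on a few compounds, and the source may have more. Where it says the series, first, only, none or still open, it means among the compounds named here.

Three compounds were measured in a functional assay on HT-29 cells (Homo sapiens) for inhibition, read by sulforhodamine B assay, with a stated time of 48 h; a lower number here means a stronger inhibitor of growth, a higher number a weaker inhibitor of growth:

compound 1 `O=c1ccoc(/C=C/c2ccccc2)c1`: 344 uM
compound 2 `COc1ccc(/C=C/c2cc(=O)cco2)cc1`: 379 uM
compound 3 `COc1ccc(/C=C/C2CC=CC(=O)O2)cc1`: 33.7 uM

Compound 1 and compound 2 share one core and differ in a single place, (methoxy in place of hydrogen on an aromatic carbon). That change gave a 1.1-fold higher number from compound 1 to compound 2 (0.04 log units; within the scatter), so in this assay the two values cannot be told apart. Compound 3 carries a different core; the difference between the two cores is not broken down here, and what the values show is that compound 3 has the lowest number of the three, its gap to compound 1 and to compound 2 lying beyond the scatter.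

Compound 4 `COc1ccc(/C=C/C2CC=CC(=O)O2)c(OC)c1` has not yet been measured in this assay. It differs from compound 3 by methoxy in place of hydrogen on an aromatic carbon. Among the measured compounds shown here, this is the same kind of change as the one from compound 1 to compound 2, but not the same: there the methoxy entered para to a group of 9 heavy atoms, here it enters ortho to a group of 9 heavy atoms and meta to a methoxy group, and on a different core.

Since the earlier step was a 1.1-fold higher number from compound 1 to compound 2 (0.04 log units; within the scatter), only a small step is expected from compound 3 to compound 4, estimated as a 1.1-fold lower number from compound 3 to compound 4 (0.02 log units; within the scatter), though the changed place and core leave room for more movement. Compound 4 is therefore expected to give about 32 uM in this assay, most likely between 12 uM and 85 uM.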

Compound 4, concentration for growth inhibition (reported as GI): 6.6 uM
The estimate for compound 4 lay 4.8-fold (0.69 log units) above the measured number; measured number below the stated range.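

In this assay, methoxy in place of hydrogen on an aromatic carbon gave a 5.1-fold lower number from compound 3 to compound 4 (0.71 log units; beyond the scatter), so the change moved the number clearly on the core of compound 3, although it had left the number unchanged within the scatter on the core of compound 1. Set side by side, the two steps show that the size of this change did not carry over from one core to the other in this series: the same change on two cores in this assay, a 1.1-fold higher number (0.04 log units; within the scatter) from compound 1 to compound 2 and a 5.1-fold lower number (0.71 log units; beyond the scatter) from compound 3 to compound 4, 5.6-fold (0.75 log units) apart, beyond the scatter of two such steps. This does not show that the core alone accounts for the gap, since the new methoxy of compound 4 also stands in its own place, ortho to a group of 9 heavy atoms and meta to a methoxy group, and a single pair of steps gives no rule for other cores or other places.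

The compounds shown leave open whether the lower number of compound 4 belongs to methoxy itself or would also come with a hydroxyl group, a chlorine atom or a longer ethoxy chain in that place. They also leave open how methoxy in that same place would behave on the core of compound 1, and whether it would give a step of this size on the core of compound 3 without the methoxy group it stands meta to.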